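Aryl swap on the shared core: methyl to methoxy

The compounds below may be only part of what the source reports. "The series", "measured", "known", "first", "only" and "open" are said of these compounds alone.

Measured compounds in an ADME assay on MT4 cells (Homo sapiens) for cytotoxicity, read by MTT assay, with a stated time of 4 days; on this read-out higher numbers stand for lower toxicity in this test and lower numbers for higher toxicity in this test:
- compound 1 `COc1ccc(-c2cc(C)c(Nc3ccnc(Nc4ccc(C#N)cc4)n3)c(C)c2)cc1`, 2890 nM
- compound 2 `Cc1cc(-c2ccccc2Cl)cc(C)c1Nc1ccnc(Nc2ccc(C#N)cc2)n1`, 3990 nM
- compound 3 `Cc1cccc(-c2cc(C)c(Nc3ccnc(Nc4ccc(C#N)cc4)n3)c(C)c2)c1`, 3670 nM

Compound 3 sits in the middle of these three numbers. Its nearest neighbour is compound 2, with a 1.1-fold lower number from compound 2 to compound 3 (0.04 log units; within the scatter), and its furthest is compound 1, with a 1.3-fold higher number from compound 1 to compound 3 (0.10 log units; within the scatter). The third measured step, a 1.4-fold higher number from compound 1 to compound 2 (0.14 log units; within the scatter), is also within the scatter, so all three aryl rings on the shared core give numbers that cannot be told apart in this assay.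

Compound 4 `COc1cccc(-c2cc(C)c(Nc3ccnc(Nc4ccc(C#N)cc4)n3)c(C)c2)c1` differs from compound 3 by a single change: methoxy in place of methyl on an aromatic carbon. Among the measured compounds shown here, no measured step repeats this exact swap. The closest comparison is the step from compound 1 to compound 3, which also exchanges a methoxy for a methyl on the outer ring, and it stayed within the scatter, as did the other two steps. The expected step of a 1.0-fold lower number from compound 3 to compound 4 (0.02 log units; within the scatter) is therefore none beyond the scatter. Compound 4 is estimated at 3500 nM, with a range from 1800 nM to 7000 nM.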

Compound 4, half-maximal cytotoxic concentration: 2990 nM
Compound 4: the middle estimate sits 1.2-fold (0.07 log units) above what was measured, and the stated range covers the measured number.
By their numbers in this assay, from the lowest: compounds 1, 4, 3 and 2 (each within the scatter of the next).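

In this assay, methoxy in place of methyl on this aromatic carbon, meta to a large group, gives a 1.2-fold lower number from compound 3 to compound 4 (0.09 log units; within the scatter) and so adds a hydrogen-bond acceptor without leaving the scatter. The new ring also stays within the scatter of the other two: 3-methoxyphenyl in place of 4-methoxyphenyl gives a 1.0-fold higher number from compound 1 to compound 4 (0.01 log units; within the scatter) and 3-methoxyphenyl in place of 2-chlorophenyl gives a 1.3-fold lower number from compound 2 to compound 4 (0.13 log units; within the scatter), so all four aryl rings on the shared core remain indistinguishable on this read-out. No measurement available here offers an explanation for this flat result.

Whether this position tolerates any group can't be judged from small neutral groups alone, so an amine or a carboxylic acid on the outer ring remains an open test. Going by these compounds, a longer chain, such as butoxy, in place of the methoxy is equally open.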